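A few compounds are considered here, and "the series" means these few. Any claim that something is new, unique, unknown or untested is made for them only; others in the source may bear on it.

Compound 1, `CS(=O)(=O)c1ccc(-c2cnc3[nH]cc(-c4nnc(-c5ccccc5)o4)c(=O)c3c2)cc1`, was examined in a functional assay on HCT-116 cells (Homo sapiens) for inhibition, read by MTT assay, with a stated time of 24 h, tested at 5 uM (a higher number here means more inhibition of growth at the concentration tested, a lower number less inhibition of growth), where compound 1 gives 8.6%. Going by the values given here, only two numbers are known so far in this assay; the other comes from compound 2, `O=c1c(-c2nnc(-c3ccc(F)cc3)o2)c[nH]c2ncc(-c3cccnc3)cc12`, which gives 11.1%, and the two values lie within the usual scatter of each other, so compound 1 stands level with compound 2 rather than apart from it. Compound 3, `Cc1ccc(-c2nnc(-c3c[nH]c4ncc(-c5ccc(S(C)(=O)=O)cc5)cc4c3=O)o2)cc1`, has not yet been measured in this assay. It differs from compound 1 in one place: methyl in place of hydrogen on an aromatic carbon, para to a large group; cut one bond further out, the change reads phenyl to 4-methylphenyl. Among the compounds with values here, no step between two measured compounds covers such a change, so nothing measured tells how far a methyl moves the number here. Both known values are low, and a single added methyl is a small change. The step expected here, a number 3.4 percentage points higher from compound 1 to compound 3 (within the scatter), is small, within the scatter, with no firm direction. Compound 3 is therefore estimated at 12%, with a likely range from 0% to 28%.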

Compound 3, percent growth inhibition at one concentration: 20.4%
For compound 3 the middle estimate is 8.4 percentage points below the measured one; the measured number falls inside the stated range.
By their numbers in this assay, from the lowest: compounds 1, 2 and 3 (each within the scatter of the next, the first and the last beyond it).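

In this assay the change from hydrogen to methyl reads as a number 11.8 percentage points higher from compound 1 to compound 3 (beyond the scatter). Going by these compounds alone, a methyl on this aromatic carbon, para to a large group, therefore moves the number by more than the scatter, which no earlier pair could show. The step is modest, however, and it rests on this single pair, so phenyl to 4-methylphenyl is shown to matter here only on the core of compound 1. No measurement at hand bears on what lies behind this step.

The compounds shown leave open whether the rise is particular to methyl or would also appear with an ethyl, a methoxy group or a chlorine atom in the same place. They also leave open whether the same methyl would give a similar step on compound 2.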